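Paw edema inhibition: the phenyl to 4-chlorophenyl step

The source may report more compounds than this note shows. Statements on the series, on what has been measured and on what is new or still open speak of the compounds shown alone.

Measured so far:
compound 1 `CC1=C(C(=O)Nc2ccc(F)cc2)C(c2ccc(Br)cc2)n2c(s/c(=C/c3ccc(Cl)cc3Cl)c2=O)=N1` gives 14%
compound 2 `CC1=C(C(=O)Nc2ccc(F)cc2)C(c2ccc(Br)cc2)n2c(s/c(=C/c3ccccc3)c2=O)=N1` gives 5%

Both numbers come from a functional assay on the whole organism (strain albino) for inhibition, with Rattus norvegicus as the target, read by paw edema, with stated times of 1 h and 3 h, at a dose of 25 mg/kg by the oral route; a lower number here means less inhibition, a higher number more inhibition at the dose given (going by the name of the read-out). Compound 2 stands lowest of the two; its nearest neighbour is compound 1, and the gap between them, a number 9 percentage points lower from compound 1 to compound 2 (within the scatter), lies within the scatter, so the two cannot be ordered. That step, phenyl in place of 2,4-dichlorophenyl on a double-bonded chain carbon bound to an aromatic carbon, is the only measured one that bears on the next compound.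

Compound 3 `CC1=C(C(=O)Nc2ccc(F)cc2)C(c2ccc(Br)cc2)n2c(s/c(=C/c3ccc(Cl)cc3)c2=O)=N1` is not yet measured. It differs from compound 2 thus: chloro in place of hydrogen on an aromatic carbon. Given that a larger change at the same ring gave only a number 9 percentage points lower from compound 1 to compound 2 (within the scatter), no step beyond the scatter is expected here; a small rise toward compound 1 is the most that is anticipated, so the step of a number 5 percentage points higher from compound 2 to compound 3 (within the scatter) is expected to be modest. In this assay compound 3 is estimated at 10%, within a range of 0% to 24%.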

Compound 3, a percentage reported as inhibition, in the whole organism at one dose (the size of the read-out at that dose, not a potency): 25%
Compound 3: middle estimate off by 15 percentage points, on the low side; measured number above the stated range.
By their numbers in this assay, from the lowest: compounds 2 and 1 (each within the scatter of the next); then compound 3.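

In this assay this position gives its first step beyond the scatter: a number 20 percentage points higher from compound 2 to compound 3 (beyond the scatter) on going from phenyl to 4-chlorophenyl, and a number 11 percentage points higher from compound 1 to compound 3 (beyond the scatter) on taking the further chloro away from the 2,4-dichlorophenyl group. The number therefore does not follow the count of chloro groups on this ring, since the single chloro stands above both the unsubstituted phenyl and the 2,4-dichlorophenyl group, while compound 1 and compound 2 cannot be ordered. No measurement on hand accounts for this rise.

Going by these compounds, whether the gain is specific to chloro stays open, as a fluoro, methoxy or dimethylamino group at the same place could show. Also open, on these data alone, is whether the order of these three compounds in this assay would hold at other doses.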